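Growth inhibition series: from compound 1 to compound 3

The source may hold more compounds than are shown below. What is called first, only, known or untested is meant among the compounds shown, and "the series" means these compounds.

- compound 1 `COc1ccc(/C=C/[C@@](C)(/C=C/c2ccc(O)cc2)CCC=C(C)C)cc1`: 20%
- compound 2 `COc1ccc(/C=C/[C@@](C)(/C=C/c2ccc(O)cc2)CCC=C(C)C)cc1C=O`: 31%

In a functional assay on HeLa cells (Homo sapiens) for inhibition, with a stated time of 48 h, tested at 50 uM (a higher number here means more inhibition of growth at the concentration tested, a lower number less inhibition of growth), compound 1 is the lower of the two measured compounds (20%), and compound 2 is the higher of the two (31%). The unmeasured compound 3 `CC(C)=CCCC(C)(/C=C/c1ccc(O)cc1)/C=C/c1ccc(O)cc1` differs from compound 1 as follows: hydrogen in place of methyl on an oxygen on an aromatic ring. For the measured compounds named here, no measured step touches this oxygen. Going by the values given here, the only step available, a number 11 percentage points higher from compound 1 to compound 2 (beyond the scatter), places formyl in place of hydrogen on an aromatic carbon, so it is only a rough guide to the size of change on this core and gives no direction. A small change is therefore expected in this assay, perhaps none beyond the scatter. The expected step is a number 3 percentage points higher from compound 1 to compound 3 (within the scatter). Compound 3 is estimated at 23%, with an expected range from 10% to 40%.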

Compound 3, percent growth inhibition at one concentration: 32%
For compound 3 the middle estimate is 9 percentage points below the measured one; the range from low to high includes it.
By their numbers in this assay, from the lowest: compound 1; then compounds 2 and 3 (each within the scatter of the next).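

In this assay, for the compounds shown here, hydrogen in place of methyl on an oxygen on an aromatic ring gives a number 12 percentage points higher from compound 1 to compound 3 (beyond the scatter), the first measured step at this oxygen. The read-out therefore responds to this position, and loss of a single methyl, one heavy atom, is enough to move it upward beyond the scatter, on the shared core of compound 1. Nothing measured accounts for this step, and no data on the compounds bear on its origin.

Open, from the compounds shown here alone, is whether the hydrogen on this oxygen is itself required, or whether an ethyl or acetyl group on the oxygen, or an amine in its place, would give a similar number. Also open, going by these compounds, is whether formyl on the aromatic carbon and hydrogen on this oxygen would add up within one compound.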